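The source may report more compounds than this note shows. Statements on the series, on what has been measured and on what is new or still open speak of the compounds shown alone.

Measured so far:
compound 1 `COc1cc(-c2nnc3n2NC(c2ccco2)C(C(=O)c2ccc(Cl)cc2)S3)cc(OC)c1OC` — 67800 nM
compound 2 `COc1cccc(C(=O)C2Sc3nnc(-c4cc(OC)c(OC)c(OC)c4)n3NC2c2ccco2)c1` — 84600 nM

For the measured compounds named here, in a functional assay on PC-3 cells (Homo sapiens) for cytotoxicity, read by MTT assay, with a stated time of 48 h (on this read-out lower numbers stand for stronger inhibition and higher numbers for weaker inhibition), compound 1 gives 67800 nM and compound 2 gives 84600 nM; the two numbers sit within the scatter of each other, so compound 1 stands level with the only other measured compound, not apart from it. Going by the values given here, the one step on record, a 1.2-fold higher number from compound 1 to compound 2 (0.10 log units; within the scatter), changes an aryl group on the same carbonyl carbon and moves the number no further than repeat measurements would.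

Compound 3 `COc1cc(-c2nnc3n2NC(c2ccco2)C(C(=O)c2ccco2)S3)cc(OC)c1OC` is not yet measured. It differs from compound 1 by furan-2-yl in place of 4-chlorophenyl on a carbonyl carbon. Among the compounds with values here, the only step that bears on this change is the aryl swap at that carbonyl carbon, a 1.2-fold higher number from compound 1 to compound 2 (0.10 log units; within the scatter), and it stayed within the scatter. Within the data shown here, no measured pair shows a furan-2-yl at this carbonyl, so the expectation rests on that one step alone.

For compound 3 the expectation in this assay is therefore a 1.0-fold higher number from compound 1 to compound 3 (0.01 log units; within the scatter), that is, no step beyond the scatter. Compound 3 is estimated at 70000 nM, with a range from 25000 nM to 200000 nM.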

Compound 3, half-maximal inhibitory concentration: 58300 nM
For compound 3 the middle estimate is 1.2-fold (0.08 log units) above the measured one; the range from low to high includes it.
By their numbers in this assay, from the lowest: compounds 3, 1 and 2 (each within the scatter of the next).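

In this assay, furan-2-yl in place of 4-chlorophenyl on the carbonyl carbon gives a 1.2-fold lower number from compound 1 to compound 3 (0.07 log units; within the scatter), and furan-2-yl in place of 3-methoxyphenyl gives a 1.5-fold lower number from compound 2 to compound 3 (0.16 log units; within the scatter), so both new steps stay within the scatter. For the compounds shown here, the earlier step compared only two six-membered aromatic rings of carbon, whereas this result extends the comparison to a five-membered aromatic ring with a hetero atom, and the number still does not move beyond the scatter. Across compound 1, compound 2 and compound 3, this position therefore shows no separation among the three aryl groups.

Still open, going by these compounds, is whether a non-aromatic group at this carbonyl carbon, such as an amine, a carboxylic acid or a longer alkyl chain, would give a step beyond the scatter, and whether changes elsewhere on the shared core would do so. No available evidence accounts for the level numbers at this position.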